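The source may hold more compounds than are shown below. What is called first, only, known or untested is meant among the compounds shown, and "the series" means these compounds.

Compound 1 `O=C(NO)c1ccc(NCc2nc(-c3ccccc3)nn2-c2ccc(Br)cc2)cc1`: 1730 nM in an assay on Sf9 cells for inhibition of protein deacetylase HDAC6 (Homo sapiens), read by fluorescence, with a stated time of 40 min; a higher number here means a weaker inhibitor, a lower number a stronger inhibitor
Compound 2 `O=C(NO)c1ccc(NCc2nc(-c3cc4ccccc4s3)nn2-c2ccccc2)cc1`: 324 nM
Compound 3 `Cc1ccc(-c2nc(CNc3ccc(C(=O)NO)cc3)n(-c3ccccc3)n2)s1`: 30.6 nM

Among the three measured compounds, compound 1 gives the highest number in this assay, so it is the weakest inhibitor of the set; compound 2 sits nearest to it and compound 3 furthest away. Within the data shown here, the one step that can be traced within the measured set is an 11-fold lower number from compound 2 to compound 3 (1.02 log units; beyond the scatter), and it concerns the aryl group on a ring carbon of the shared core, not the group on the ring nitrogen.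

Compound 4 `O=C(NO)c1ccc(NCc2nc(-c3ccccc3)nn2-c2ccccc2Cl)cc1` differs from compound 1 by 2-chlorophenyl in place of 4-bromophenyl on an aromatic nitrogen. Among the measured compounds shown here, no measured pair changes this group alone, so the step from compound 2 to compound 3 does not bear on it directly, and nothing in the data shows how a halogen moved from one ring position to another affects the number. Compound 4 is therefore expected to stay close to compound 1, with the step of a 1.3-fold lower number from compound 1 to compound 4 (0.12 log units; within the scatter) judged unlikely to exceed the scatter. For compound 4 the estimate is 1300 nM, within 400 nM to 4000 nM.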

Compound 4, half-maximal inhibitory concentration: 669 nM
Compound 4: the middle estimate sits 1.9-fold (0.29 log units) above what was measured; measured number inside the range.
By their numbers in this assay, from the lowest: compound 3; then compound 2; then compound 4; then compound 1.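

In this assay the exchange of the aryl group on the aromatic nitrogen gives a 2.6-fold lower number from compound 1 to compound 4 (0.41 log units; beyond the scatter), which shows that the number responds to this position, one the earlier step between measured compounds did not touch, even though the leaving and entering groups have the same count of heavy atoms. The exchange replaces bromine with chlorine and also changes the halogen's place on the phenyl ring, so this single step cannot be assigned to either change alone. Nothing available explains the step.

The compounds shown leave open what 2-bromophenyl or 4-chlorophenyl would give on this nitrogen alongside the same phenyl group on the ring carbon. They also leave open how an unsubstituted phenyl, or a phenyl carrying a methoxy group or an amine, would behave here.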